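Adding a methyl to an inactive hydroxyurea amide series

The source may report more compounds than this note shows. Statements on the series, on what has been measured and on what is new or still open speak of the compounds shown alone.

Compound 3 `CC(C)C(NC(=O)NO)C(=O)NC1CCCC1` is one of three close analogues that share a hydroxyurea attached to an amino-acid-derived amide. In a functional assay on SW-620 cells (Homo sapiens) for inhibition (a lower number here means a stronger inhibitor, a higher number a weaker inhibitor), compound 3 gives > 100000 nM, which is a limit of the assay and not a measured number. Compound 1 `CC(C)C(NC(=O)NO)C(=O)NC1CCCCC1` carries a cyclohexyl on the amide-type nitrogen; in this assay compound 1 gives > 100000 nM, again a limit. Compound 2 `CCC(C)C(NC(=O)NO)C(=O)NC1CCCCC1` gives > 100000 nM, also a limit. All three values sit at the same ceiling, (the limit of > 100000 nM in this assay, at which 3 of the 3 values shown sit), so the step that the two limits leave unreadable from compound 1 to compound 3 cannot be read in size.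

Compound 4 `CCC(C)C(NC(=O)NO)C(=O)NC1CCCC1` differs from compound 3 by methyl in place of hydrogen on a saturated chain carbon, three bonds along the chain from an amide-type nitrogen and a carbonyl carbon. The same change has been made once before, from compound 1 to compound 2, where the step was a step that the two limits leave unreadable from compound 1 to compound 2. That step is unreadable because both ends sit at the limit of > 100000 nM in this assay, at which 3 of the 3 values shown sit, and it gives no sign that the methyl moves the inhibition into the measurable range. The cyclopentyl pairing of compound 3 offers nothing further. Compound 4 is therefore expected to remain at the ceiling, with an expected step that the limit leaves unreadable from compound 3 to compound 4. The estimate for compound 4 is 300000 nM, within a range from 100000 nM to 1000000 nM.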

Compound 4, half-maximal inhibitory concentration: > 100000 nM
Compound 4: only a limit was reported; the forecaster's own chance of this, stated with the estimate: 90%; the middle value is on the limit's open side.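

In this assay compound 4 gives > 100000 nM, which is a limit. The steps to compound 4 from compound 3 and from compound 2 cannot be read in size, because both ends of each sit at the ceiling: the limit of > 100000 nM in this assay, at which 4 of the 4 values shown sit.

The compounds shown leave open whether any change to this series reaches the measurable range.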